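The source may hold more compounds than are shown below. What is called first, only, known or untested is meant among the compounds shown, and "the series" means these compounds.

Measured in a functional assay on A-375 cells (Homo sapiens) for activation, with a stated time of 3 days; a higher number here means that more compound is needed for the effect, a lower number that less compound is needed:
- Compound 1 `O=C(Nc1ccc(-c2cscn2)cc1)C1CCCN(Cc2ccc(F)c(F)c2)C1`: 1240 nM.
- Compound 2 `O=C(Nc1ccc(-c2cscn2)cc1)C1CCCN(Cc2ccc(F)cc2)C1`: 5000 nM.
- Compound 3 `O=C(Nc1ccc(-c2cscn2)cc1)C1CCCN(Cc2cccc(C(F)(F)F)c2)C1`: > 20000 nM, a limit and not a number.

Compound 3 stands at the high end of this set, with only a limit to show (the limit of > 20000 nM in this assay, at which 1 of the 3 values shown sits). Compound 4 `O=C(Nc1ccc(-c2cscn2)cc1)C1CCCN(Cc2ccc3cn[nH]c3c2)C1` has 1H-indazol-6-yl in place of 3-(trifluoromethyl)phenyl on a saturated chain carbon bound to an amine nitrogen in a ring. Swaps at this same place gave a large step, an at least 16-fold higher number from compound 1 to compound 3 (1.20 log units; beyond the scatter), and an at least modest one, an at least 4.0-fold higher number from compound 2 to compound 3 (0.60 log units; beyond the scatter). Neither involves 1H-indazol-6-yl, so they guide the size only loosely. The expected result is a modest move to a lower number, an at least 4.0-fold lower number from compound 3 to compound 4 (0.60 log units; beyond the scatter). For compound 4 the estimate in this assay is 5000 nM, with an expected range of 1200 nM to 20000 nM.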

Compound 4, half-maximal effective concentration: > 20000 nM
Compound 4 was reported as a limit; the forecaster's own chance of this, stated with the estimate: 25%; middle value at least 4.0-fold (0.60 log units) away from the limit.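

In this assay compound 4 gives > 20000 nM, a limit and not a number, so the step from compound 3 cannot be read. Against the fluorophenyl compounds, the two-ring 1H-indazol-6-yl shows a clear loss, with an at least 4.0-fold higher number from compound 2 to compound 4 (0.60 log units; beyond the scatter) and an at least 16-fold higher number from compound 1 to compound 4 (1.20 log units; beyond the scatter). A group with a hydrogen-bond donor and acceptor therefore ends at the same ceiling as 3-(trifluoromethyl)phenyl, which has neither: the limit of > 20000 nM in this assay, at which 2 of the 4 values shown sit.

As far as these compounds go, how far compound 3 and compound 4 each lie beyond that ceiling stays unknown. Also open, from the compounds shown here alone, is whether a pyridine ring or a methoxy group at this place would give a lower number than compound 1.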